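From isopropyl to 1-methylethenyl, with one number to go on

The source may report more compounds than this note shows. Statements on the series, on what has been measured and on what is new or still open speak of the compounds shown alone.

Compound 1 `O=C(O)[C@H](CO)NC(=O)N1CCCC1` gives "not determined" (no result reported)
Compound 2 `COC(=O)C(=O)N[C@@H](CO)C(=O)O` gives "not determined" (no result reported)
Compound 3 `CC(C)C(=O)N[C@@H](CO)C(=O)O` gives 49%

Among the compounds with values here, in an ADME assay on microsomes from liver (Mus musculus) for metabolic stability, with a stated time of 30 min (a higher number here means that more of the compound is left, a lower number that less of the compound is left), compound 3 gives 49% as the only number in this small set. Compound 1 and compound 2 have no reported result, so compound 3 cannot be ranked against either. Compound 4 `C=C(C)C(=O)N[C@@H](CO)C(=O)O` carries 1-methylethenyl in place of isopropyl on a carbonyl carbon and is otherwise unchanged. Within the data shown here, no measured pair shows what such a swap does. The expectation is therefore no shift beyond the usual scatter, in either direction, and it rests on compound 3 at 49% alone. The estimated move is a number 2 percentage points lower from compound 3 to compound 4 (within the scatter) and stays within that scatter. For compound 4 the expected value is 47% with an estimated range from 30% to 65% in this assay.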

Compound 4, percent of the compound remaining: 68%
Compound 4: middle estimate off by 21 percentage points, on the low side; measured number above the stated range.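

Within the data shown here, the change to 1-methylethenyl in place of isopropyl on a carbonyl carbon gives a number 19 percentage points higher from compound 3 to compound 4 (beyond the scatter) in this assay and so provides the first measured step at this position. It shows that the read-out responds to this change, even though both groups have the same heavy-atom count and the entering group differs by a double bond outside aromatic rings. No evidence bears on the reason for this step. As far as these compounds go, whether a longer chain, a cyclopropyl ring or an amine at this position would move the read-out in the same direction remains open, as does whether this step would recur on another core.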